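Adding Chlorine to the Benzyl Group of Compound 3

The source may hold more compounds than are shown below. What is called first, only, known or untested is meant among the compounds shown, and "the series" means these compounds.

The study compares three measured analogues on a shared core. Compound 1 `CC(C)c1ccc(-c2nc(N)c3cc(Cc4ccccc4)sc3n2)o1` gives 283 nM in a functional assay on CHO-K1 cells for antagonist activity at adenosine receptor A1 (Homo sapiens), read by a beta-galactosidase reporter and cAMP accumulation, with stated times of 15 min and 6 h; on this read-out higher numbers stand for weaker inhibition and lower numbers for stronger inhibition. Compound 2 `Nc1nc(-c2ccc(C3CC3)o2)nc2sc(Cc3ccccc3)cc12` gives 861 nM in this assay, and compound 3 `N#Cc1cccc(-c2nc(N)c3cc(Cc4ccccc4)sc3n2)c1` gives 222 nM. Compound 3 has the lowest number of the three; its distance to compound 1 is within the scatter, while a 3.9-fold lower number from compound 2 to compound 3 (0.59 log units; beyond the scatter) and a 3.0-fold higher number from compound 1 to compound 2 (0.48 log units; beyond the scatter) lie beyond it.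

Compound 4 `N#Cc1cccc(-c2nc(N)c3cc(Cc4ccccc4Cl)sc3n2)c1` differs from compound 3 by chloro in place of hydrogen on an aromatic carbon. Among the measured compounds shown here, none of the measured steps touches this part of the molecule: all three concern the group on the other aromatic carbon of the core, so no measured step bears directly on the change. The expectation for compound 4 is therefore anchored on compound 3 and 222 nM, with a 1.1-fold lower number from compound 3 to compound 4 (0.02 log units; within the scatter) expected to stay within the scatter in this assay. Compound 4 is thus estimated at 210 nM in this assay, with a range from 70 nM to 630 nM.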

Compound 4, inhibition constant: 24.8 nM
Compound 4: the middle estimate sits 8.5-fold (0.93 log units) above what was measured; measured number outside the range, below it.
By their numbers in this assay, from the lowest: compound 4; then compounds 3 and 1 (each within the scatter of the next); then compound 2.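

In this assay, among the compounds shown here, there is a 9.0-fold lower number from compound 3 to compound 4 (0.95 log units; beyond the scatter) with benzyl going to 2-chlorobenzyl, which shows that this part of the molecule, untouched by the earlier steps, responds to a single chloro on the six-membered aromatic ring, ortho to a large group. The earlier steps shown here all changed the group on the other aromatic carbon of the core, and the largest of them, a 3.9-fold lower number from compound 2 to compound 3 (0.59 log units; beyond the scatter) in the same assay, is smaller than this one. The compounds shown offer no evidence on the reason for this step.

On these data alone, it remains open whether a fluoro, methyl or methoxy group at the same place would give a comparable step. As far as these compounds go, it is also open whether 2-chlorobenzyl would have a similar effect with the 5-isopropylfuran-2-yl group of compound 1 in place of 3-cyanophenyl.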